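The source may report more compounds than this note shows. Statements on the series, on what has been measured and on what is new or still open speak of the compounds shown alone.

Compounds measured so far in a functional assay on SK-MEL-5 cells (Homo sapiens) for inhibition, read by sulforhodamine B assay, with a stated time of 48 h; on this read-out lower numbers stand for higher toxicity in this test and higher numbers for lower toxicity in this test:

Compound 1, `O=C(Nc1cccc(-n2cc(-c3ccncc3)c(-c3ccc(Cl)c(O)c3)n2)c1)Nc1cccc(C(F)(F)F)c1`, gives 13800 nM.
Compound 2, `COc1cc(-c2nn(-c3cccc(NC(=O)Nc4cc(C(F)(F)F)cc(C(F)(F)F)c4)c3)cc2-c2ccncc2)ccc1Cl`, gives 2670 nM.
Compound 3, `COc1cc(-c2nn(-c3cccc(NC(=O)Nc4cccc(C(F)(F)F)c4)c3)cc2-c2ccncc2)ccc1Cl`, gives 2680 nM.

Compound 3 stands second highest of the three numbers, yet its nearest neighbour is compound 2, and the step from compound 2 to compound 3 is a 1.0-fold higher number from compound 2 to compound 3 (0.00 log units; within the scatter), so the two cannot be set in order. For the measured compounds named here, the only step beyond the scatter is a 5.1-fold lower number from compound 1 to compound 3 (0.71 log units; beyond the scatter), where a methyl replaces a hydrogen on an oxygen on an aromatic ring.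

Compound 4, `COc1cc(-c2nn(-c3cccc(NC(=O)Nc4ccc(Cl)c(C(F)(F)F)c4)c3)cc2-c2ccncc2)ccc1Cl`, has not yet been measured. It differs from compound 3 by chloro in place of hydrogen on an aromatic carbon. This change sits on the same ring that was altered between compound 2 and compound 3, where a trifluoromethyl in place of a hydrogen left the number unchanged within the scatter. That step is the one that bears on the present change; the step from compound 1 to compound 3 concerns another ring and is not informative here. A small substituent entering beside an unchanged result gives no ground to expect a shift beyond the scatter.

The estimated step from compound 3 to compound 4 in this assay is therefore a 1.2-fold lower number from compound 3 to compound 4 (0.07 log units; within the scatter). Compound 4 is expected at about 2300 nM, with a range from 900 nM to 5800 nM.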

Compound 4, concentration lethal to 50% of the cells: 10400 nM
Estimate against measurement, compound 4: 4.5-fold (0.66 log units) below; measured number above the stated range.
By their numbers in this assay, from the lowest: compounds 2 and 3 (each within the scatter of the next); then compounds 4 and 1 (each within the scatter of the next).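

Read in this assay, the step of a 3.9-fold higher number from compound 3 to compound 4 (0.59 log units; beyond the scatter) shows that a chloro at this place, ortho to a trifluoromethyl group and para to a large group, moves the number beyond the scatter, toward lower toxicity in this test. The earlier change on this ring, a 1.0-fold higher number from compound 2 to compound 3 (0.00 log units; within the scatter), stayed within the scatter, so that silent result concerned a trifluoromethyl leaving and does not hold for a chloro entering at this place. No measurement offered here accounts for the rise in the number.

From the compounds shown here alone, whether the shift belongs to chloro itself or to this place on the ring stays open, and a fluoro, a methyl, a methoxy or an amine at the same carbon would be needed to tell these apart. Going by these compounds, it also remains open whether the same chloro would produce a step of similar size on the compound with the free hydroxyl or on the one carrying the second trifluoromethyl.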